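A few compounds are considered here, and "the series" means these few. Any claim that something is new, unique, unknown or untested is made for them only; others in the source may bear on it.

Measured compounds: compound 1 `CCOc1c(-c2cc(OC)c(OC)c(OC)c2)oc2ccccc2c1=O`; compound 2 `CCCCCCCOc1c(-c2cc(OC)c(OC)c(OC)c2)oc2ccccc2c1=O`; compound 3 `CCN(CC)CCCCOc1c(-c2cc(OC)c(OC)c(OC)c2)oc2ccccc2c1=O`.

In a functional assay on LNCaP cells (Homo sapiens) for antiproliferative activity, read by WST assay, with a stated time of 3 days (on this read-out higher numbers stand for weaker inhibition and lower numbers for stronger inhibition), compound 1 gives 5400 nM, the lowest of the two numbers reported. Compound 3 gives 13500 nM in this assay. Compound 2 reaches only the limit of > 50000 nM in this assay, so for it no number is known (the limit of > 50000 nM in this assay, at which 1 of the 3 values shown sits).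

The unmeasured compound 4 `CCCCN(CCCC)CCCOc1c(-c2cc(OC)c(OC)c(OC)c2)oc2ccccc2c1=O` differs from compound 1 by (dibutylamino)methyl in place of hydrogen on a saturated chain carbon, two bonds along the chain from an oxygen on an aromatic ring. Two measured steps from compound 1 bear on this change, both adding a chain at the same place. Adding a plain pentyl gave an at least 9.2-fold higher number from compound 1 to compound 2 (0.96 log units; beyond the scatter), while adding a 2-(diethylamino)ethyl gave a 2.5-fold higher number from compound 1 to compound 3 (0.40 log units; beyond the scatter). Between those two, an at least 3.7-fold lower number from compound 2 to compound 3 (0.56 log units; beyond the scatter) shows the amine-bearing chain faring better than the all-carbon one. The (dibutylamino)methyl group of compound 4 carries an amine but is longer and carries more carbon than the chain in compound 3, so a step larger than that to compound 3 and smaller than that to compound 2 is expected.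

Compound 4 is therefore expected to show a 3.7-fold higher number from compound 1 to compound 4 (0.57 log units; beyond the scatter). In this assay compound 4 is estimated at 20000 nM, within a range from 7000 nM to 55000 nM.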

Compound 4, half-maximal inhibitory concentration: 9000 nM
Compound 4: the middle estimate sits 2.2-fold (0.35 log units) above what was measured, and the stated range covers the measured number.
By their numbers in this assay, from the lowest: compounds 1, 4 and 3 (each within the scatter of the next, the first and the last beyond it). At a limit, above all of these: compound 2.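

Adding (dibutylamino)methyl at this place, on a saturated chain carbon two bonds along the chain from an oxygen on an aromatic ring, gives in this assay a 1.7-fold higher number from compound 1 to compound 4 (0.22 log units; within the scatter), and the comparison with the other amine-bearing chain gives a 1.5-fold lower number from compound 3 to compound 4 (0.18 log units; within the scatter), so the larger amine chain brought no measurable loss, unlike the earlier step to compound 3, which lay beyond the scatter. A second amine-bearing chain also separates from the all-carbon chain, with an at least 5.5-fold lower number from compound 2 to compound 4 (0.74 log units; beyond the scatter), so the earlier contrast between compound 2 and compound 3 is not confined to one amine. That contrast still rests on a limit and not on a number for compound 2: the limit of > 50000 nM in this assay, at which 1 of the 4 values shown sits.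

Compound 3 and compound 4 differ both in the chain leading to the amine and in the groups on its nitrogen, so the contribution of each stays unresolved. As far as these compounds go, whether a ring amine such as piperidine or morpholine, or a hydroxyl at the end of the chain, would give a number lower than that of compound 1 also stays open.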